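A few compounds are considered here, and "the series" means these few. Any claim that something is new, unique, unknown or untested is made for them only; others in the source may bear on it.

Going by the values given here, in an ADME assay on microsomes from liver (Rattus norvegicus) for metabolic stability, with a stated time of 60 min, tested at 1 uM (on this read-out lower numbers stand for a less stable compound and higher numbers for a more stable compound), compound 1 `COc1cc(-c2cnn3cc(OC)c(-c4cnn(C)c4)nc23)ccn1` gives 56%, the highest of the three numbers so far. Compound 2 `COc1cc(-c2cnn3cc(OC)c(C4CCOC4)nc23)ccn1` gives 34%, and compound 3 `COc1cc(-c2cnn3cc(OC)c(C)nc23)ccn1` gives 13%.

Compound 4 `COc1cn2ncc(-c3ccnc(OC4CC4)c3)c2nc1-c1cnn(C)c1` keeps the core of compound 1 and alters one group: cyclopropyl in place of methyl on an oxygen on an aromatic ring. Put simply, methoxy becomes cyclopropyloxy.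

The measured steps all concern a different place, a group on an aromatic carbon. They are a number 22 percentage points lower from compound 1 to compound 2 (beyond the scatter), a number 21 percentage points lower from compound 2 to compound 3 (beyond the scatter) and a number 43 percentage points lower from compound 1 to compound 3 (beyond the scatter). All three lie beyond the scatter, modest in the first two and large in the last, so these compounds can differ clearly in this assay. None of them, however, tests a change on the oxygen, so the data give no direction for this one, and no shift beyond the scatter is expected.

The estimated change is a number 6 percentage points lower from compound 1 to compound 4 (within the scatter), which is small and within the scatter. For compound 4 the expected value is 50%, with an estimated range from 28% to 72%.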

Compound 4, percent of the compound remaining: 32%
Compound 4: middle estimate off by 18 percentage points, on the high side; low and high end bracket the measured number.
By their numbers in this assay, from the lowest: compound 3; then compounds 4 and 2 (each within the scatter of the next); then compound 1.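

In this assay, cyclopropyl in place of methyl on an oxygen on an aromatic ring gives a number 24 percentage points lower from compound 1 to compound 4 (beyond the scatter) and so moves the compound towards the less stable end of the read-out. Going by these compounds alone, this is the first measured step at this oxygen, and it shows that the group there, and not only the group on the aromatic carbon, can shift the percent remaining beyond the scatter. Nothing measured here explains the drop.

On these data alone, whether the drop belongs to the three-membered ring itself or to any larger group on the oxygen stays open, and an ethyl or isopropyl group there would help separate the two. As far as these compounds go, it is also open whether cyclopropyloxy would lower the number in the same way with oxolan-3-yl or methyl on the aromatic carbon.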